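Series notes: the step from compound 3 to compound 4

The source may report more compounds than this note shows. Statements on the series, on what has been measured and on what is new or still open speak of the compounds shown alone.

In an ADME assay on microsomes from liver (Homo sapiens) for metabolic stability, using NADPH, with a stated time of 10 min (on this read-out lower numbers stand for a less stable compound and higher numbers for a more stable compound), compound 1 `NC(=O)NC/C=C\CN(C[C@H]1Cc2ncccc2CN1)[C@H]1CCCc2cccnc21` gives 100%, compound 2 `CN(CCCCN(C[C@H]1Cc2ncccc2CN1)[C@H]1CCCc2cccnc21)C1CCC(F)(F)CC1` gives 61% and compound 3 `c1cnc2c(c1)CN[C@@H](CN(CCCCNC1CCOCC1)[C@H]1CCCc3cccnc31)C2` gives 97%. Compound 3 is therefore not separated from compound 1 by more than the scatter, and it lies well clear of compound 2 on the high side.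

Compound 4 `c1cnc2c(c1)CN[C@@H](CN(CCCC1CCNCC1)[C@H]1CCCc3cccnc31)C2` carries piperidin-4-yl in place of ((oxan-4-yl)amino)methyl on a saturated chain carbon, three bonds along the chain from an amine nitrogen. Among the measured compounds shown here, no measured compound carries piperidin-4-yl, so the evidence is indirect. For the measured compounds named here, two measured steps bear on the change, each replacing a group on the chain. One is a number 3 percentage points lower from compound 1 to compound 3 (within the scatter), a small step. The other is a number 36 percentage points higher from compound 2 to compound 3 (beyond the scatter), a large step that replaces a six-membered non-aromatic ring of carbon only. Compound 4 has no such ring and keeps one six-membered non-aromatic ring with 1 hetero atom, as compound 3 does.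

In this assay, the expected change is a number 7 percentage points lower from compound 3 to compound 4 (within the scatter), so no step beyond the scatter is expected, although the low number of compound 2 at 61% leaves some risk on the downward side. For compound 4 the estimated value is 90%, with an expected range of 68% to 100%.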

Compound 4, percent of the compound remaining: 100%
Estimate against measurement, compound 4: 10 percentage points below; measured number inside the range.
By their numbers in this assay, from the lowest: compound 2; then compounds 3, 1 and 4 (each within the scatter of the next).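

In this assay, the step of a number 3 percentage points higher from compound 3 to compound 4 (within the scatter) shows that, on a saturated chain carbon, three bonds along the chain from an amine nitrogen, piperidin-4-yl can take the place of ((oxan-4-yl)amino)methyl with no shift beyond the scatter, even though the ring oxygen is gone and the ring now holds the nitrogen. Among the compounds shown here, the other two steps place the new group on both sides of the earlier comparison: a number 39 percentage points higher from compound 2 to compound 4 (beyond the scatter) is a large step like the one seen with compound 3, while no change at the digits printed from compound 1 to compound 4 (within the scatter) shows a group with one six-membered non-aromatic ring matching a group with no ring on this read-out. Nothing available explains why these groups read as they do.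

The compounds shown do not separate the two fluorines of compound 2 from its carbon-only ring or its methylated chain amine as the feature that goes with its position apart from the others. A cyclohexyl group without fluorine, or a piperidin-4-yl with a methyl on its ring nitrogen, on the same chain would address that question.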